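Fluoro added to the core of compound 1

This account rests on a few compounds, and the source may have more. Where it says the series, first, only, none or still open, it means among the compounds named here.

Measured in a functional assay on PC-3 cells (Homo sapiens) for cytotoxicity, read by MTT assay, with a stated time of 72 h; a higher number here means a weaker inhibitor, a lower number a stronger inhibitor:
compound 1 `CNC(=O)c1cc(Oc2ccc(NC(=O)c3cc(-c4ccc(C)cc4)ncn3)cc2)ccn1`: > 100000 nM (a limit)
compound 2 `CCc1ccc(-c2cc(C(=O)Nc3ccc(Oc4ccnc(C(=O)NC)c4)cc3)ncn2)cc1`: 29300 nM
compound 3 `CNC(=O)c1cc(Oc2ccc(NC(=O)c3cc(-c4ccccc4)ncn3)cc2)ccn1`: 44200 nM

Compound 1 is known only as a limit (> 100000 nM). Both other compounds give numbers on the stronger side of it.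

Compound 4 `CNC(=O)c1cc(Oc2ccc(NC(=O)c3cc(-c4ccc(C)cc4)ncn3)cc2F)ccn1` differs from compound 1 by fluoro in place of hydrogen on an aromatic carbon, ortho to a (2-(methylcarbamoyl)pyridin-4-yl)oxy group. For the measured compounds named here, no measured step touches this place. Going by the values given here, the only guides are changes at another group: an at least 3.4-fold lower number from compound 1 to compound 2 (0.53 log units; beyond the scatter) and an at least 2.2-fold lower number from compound 1 to compound 3 (0.35 log units; beyond the scatter), while a 1.5-fold higher number from compound 2 to compound 3 (0.18 log units; within the scatter). A single small change can therefore leave the limit, so a modest step to a lower number in this assay is expected, or none beyond the scatter. The expected change is an at least 1.4-fold lower number from compound 1 to compound 4 (0.15 log units; that floor lies within the scatter). Compound 4 is estimated at 70000 nM, within a range from 25000 nM to 100000 nM.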

Compound 4, half-maximal inhibitory concentration: 40200 nM
The estimate for compound 4 lay 1.7-fold (0.24 log units) above the measured number; low and high end bracket the measured number.
By their numbers in this assay, from the lowest: compounds 2, 4 and 3 (each within the scatter of the next). At a limit, above all of these: compound 1.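

In this assay, for the compounds shown here, fluoro in place of hydrogen on an aromatic carbon, ortho to a (2-(methylcarbamoyl)pyridin-4-yl)oxy group, gives an at least 2.4-fold lower number from compound 1 to compound 4 (0.39 log units; beyond the scatter) and so shows that this position, untouched by the earlier steps, also responds to a single change. The size of this step is only a floor, because compound 1 is known only as a limit: the limit of > 100000 nM in this assay, at which 1 of the 4 values shown sits.

From the compounds shown here alone, whether chloro or methoxy at this place would give a similar step remains open. So does the effect of fluoro here when the ethyl group of compound 2 stands at the other place.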